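This account rests on a few compounds, and the source may have more. Where it says the series, first, only, none or still open, it means among the compounds named here.

In an ADME assay on TERT-RPE1 cells (Homo sapiens) for cytotoxicity, read by MTT assay, with a stated time of 72 h (on this read-out lower numbers stand for stronger inhibition and higher numbers for weaker inhibition), compound 1 `C=CC/N=C1\S/C(=C\c2ccc(OC)cc2)C(=O)N1C` gives > 100000 nM, which is a limit of the assay and not a number. That places compound 1 at the limit of > 100000 nM in this assay, at which 1 of the 3 values shown sits.

Compound 4 `COc1ccc(/C=C2\S/C(=N\c3ccc(Br)cc3)N(C)C2=O)cc1` has not yet been measured. It follows from compound 1 by the change (4-bromophenyl in place of allyl on a double-bonded nitrogen), that is, 4-bromophenyl in place of allyl on a double-bonded nitrogen. For the measured compounds named here, no measured step covers this exchange directly.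

The nearest evidence comes from two compounds that carry an aromatic ring on that nitrogen, although their cores also differ from the core of compound 1. Compound 2 `COc1ccc(/C=C2/CN(C)/C(=N/c3ccc(C)cc3)S2)cc1` gives 65700 nM in this assay. Compound 3 `COc1ccc(/C=C2/CN(C)/C(=N/c3ccc(F)cc3)S2)cc1` gives 42800 nM. Fluoro in place of methyl on an aromatic carbon gives a 1.5-fold lower number from compound 2 to compound 3 (0.19 log units; within the scatter), so the one measured step shows no effect of that ring substituent beyond the scatter.

On that basis, a modest move towards a lower number is expected, and the value may still reach the limit. The expected change is an at least 2.2-fold lower number from compound 1 to compound 4 (0.34 log units; beyond the scatter). Compound 4 is estimated at 45000 nM. The expected range for compound 4 runs from 15000 nM to 100000 nM.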

Compound 4, half-maximal inhibitory concentration: > 100000 nM
Compound 4: no number, only a limit; the forecaster's own chance of this, stated with the estimate: 30%; at least 2.2-fold (0.34 log units) between middle value and limit.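

Compound 4 gives > 100000 nM in this assay, which is a limit of the assay and not a number. No step from compound 1 to compound 4 can be read, because both stand at the same limit: the limit of > 100000 nM in this assay, at which 2 of the 4 values shown sit.

The compounds shown leave open whether 4-bromophenyl in place of allyl on a double-bonded nitrogen changes the read-out at all.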